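Adding a methyl to the phenyl ring of compound 3

The source may hold more compounds than are shown below. What is called first, only, known or untested is meant among the compounds shown, and "the series" means these compounds.

Measured so far in a functional assay on RPMI 8402 cells (Homo sapiens) for cytotoxicity; a lower number here means a stronger inhibitor, a higher number a weaker inhibitor:
compound 1 `Cc1ccccc1-c1nc2cc(-c3nc4cc(C#N)ccc4[nH]3)ccc2[nH]1`, 1200 nM
compound 2 `Cc1ccccc1-c1nc2cc(-c3nc4cc(C(N)=O)ccc4[nH]3)ccc2[nH]1`, 8200 nM
compound 3 `CN1CCN(c2ccc3[nH]c(-c4ccc5[nH]c(-c6ccccc6)nc5c4)nc3c2)CC1`, 490 nM

Compound 3 gives the lowest number of the three; compound 1 stands nearest, compound 2 furthest. Within the data shown here, the only single-point step recorded, a 6.8-fold higher number from compound 1 to compound 2 (0.83 log units; beyond the scatter), concerns a different change and does not bear on the present one. Compound 4 `Cc1ccccc1-c1nc2cc(-c3nc4cc(N5CCN(C)CC5)ccc4[nH]3)ccc2[nH]1` differs from compound 3 by methyl in place of hydrogen on an aromatic carbon. Among the measured compounds shown here, compounds 1 and 2 both carry the 2-methylphenyl, yet their other substituents also differ from compound 3, so no measured pair isolates this change. With nothing directly bearing on it, the step in this assay from compound 3 to compound 4 is expected to stay within the scatter, a 1.0-fold higher number from compound 3 to compound 4 (0.01 log units; within the scatter). Compound 4 is therefore estimated at 500 nM, ranging from 200 nM to 1500 nM.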

Compound 4, half-maximal inhibitory concentration: 590 nM
Compound 4: middle estimate off by 1.2-fold (0.07 log units), on the low side; the range from low to high includes it.
By their numbers in this assay, from the lowest: compounds 3 and 4 (each within the scatter of the next); then compound 1; then compound 2.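

In this assay, among these compounds, the pair compound 3 and compound 4 isolates phenyl to 2-methylphenyl for the first time, and the step (a 1.2-fold higher number from compound 3 to compound 4 (0.08 log units; within the scatter)) shows no change from this methyl. With the 2-methylphenyl held fixed, 4-methylpiperazin-1-yl in place of carbamoyl gives a far larger step (a 14-fold lower number from compound 2 to compound 4 (1.14 log units; beyond the scatter)), and in place of cyano a smaller one that still lies beyond the scatter (a 2.0-fold lower number from compound 1 to compound 4 (0.31 log units; beyond the scatter)). Nothing measured here gives a reason for these steps. Still open, going by these compounds, is whether a methoxy or a chlorine on that phenyl ring, or a primary amine or a longer alkyl chain in place of the 4-methylpiperazin-1-yl, would shift the number.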